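Methyl to hydrogen on the pendant phenyl

The source may hold more compounds than are shown below. What is called first, only, known or untested is meant among the compounds shown, and "the series" means these compounds.

Measured compounds:
compound 1, `Fc1ccc(-c2cn(-c3ccnc4cc(Cl)ccc34)nn2)cc1`: > 3080000 nM
compound 2, `Cc1ccc(-c2cn(-c3ccnc4cc(Cl)ccc34)nn2)cc1`: 352000 nM

Within the data shown here, in an ADME assay on HepG2 cells (Homo sapiens) for cytotoxicity, read by MTT assay, with a stated time of 24 h (on this read-out lower numbers stand for higher toxicity in this test and higher numbers for lower toxicity in this test), compound 2 gives 352000 nM, the only number in the set. For compound 1 the value > 3080000 nM is a limit of this assay and not a number (the limit of > 3080000 nM in this assay, at which 1 of the 2 values shown sits). Among the measured compounds shown here, the single measured step, an at least 8.7-fold lower number from compound 1 to compound 2 (0.94 log units; beyond the scatter), runs from that limit down to the number of compound 2. Compound 3, `Clc1ccc2c(-n3cc(-c4ccccc4)nn3)ccnc2c1`, differs from compound 2 by hydrogen in place of methyl on an aromatic carbon; the same difference, cut one bond further out, reads 4-methylphenyl to phenyl. For the measured compounds named here, no measured step removes a methyl in this way; the fluoro-to-methyl step bears on it only as a sign that a change at this aromatic carbon can shift the number well beyond the scatter. For compound 3 a modest rise in the number is expected, a 1.7-fold higher number from compound 2 to compound 3 (0.23 log units; within the scatter), with wide uncertainty. Compound 3 is estimated at 600000 nM, between 200000 nM and 3080000 nM.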

Compound 3, half-maximal cytotoxic concentration: 574000 nM
For compound 3 the middle estimate is 1.0-fold (0.02 log units) above the measured one, and the stated range covers the measured number.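

In this assay, the swap between methyl and hydrogen, on an aromatic carbon para to a large group, does not separate the two compounds: a 1.6-fold higher number from compound 2 to compound 3 (0.21 log units; within the scatter). Compound 3 also gives the series its unsubstituted reference, against which the fluoro compound stands apart in the same way as against the methyl compound: an at least 5.3-fold lower number from compound 1 to compound 3 (0.72 log units; beyond the scatter). For compound 1 the value is a limit of the assay and not a number: the limit of > 3080000 nM in this assay, at which 1 of the 3 values shown sits.

Going by these compounds, how far the fluoro compound actually lies from the other two stays open, since only a minimum size is known for that gap. Also open, on these data alone, is how this carbon would read with an amine, a carboxylic acid or a longer chain in place of hydrogen, and whether such groups would move the number beyond the scatter.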